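The source may report more compounds than this note shows. Statements on the series, on what has been measured and on what is new or still open speak of the compounds shown alone.

Measured so far in an assay on cell membranes for displacement of a labelled ligand from corticotropin-releasing factor receptor 1 (Rattus norvegicus); a lower number here means a stronger inhibitor, a higher number a weaker inhibitor:
compound 1 `CCC(CC)Nc1nc(C)nc2c(-c3ccc(OC)nc3C)c(C)nn12`: 3.1 nM
compound 2 `CCC[C@H](C)Nc1nc(C)nc2c(-c3ccc(OC)nc3C)c(C)nn12`: 4.5 nM

For the measured compounds named here, compound 2 and compound 1 sit within the scatter of each other; the only step between them, a 1.5-fold higher number from compound 1 to compound 2 (0.16 log units; within the scatter), is no larger than what repeat measurements of this kind give. Next in the series is compound 3 `CCCC(C)Nc1nc(C)nc2c(-c3ccc(OC)nc3C)c(C)nn12`. Relative to compound 2 the change is the two compounds have the same atoms and bonds; at least one stereo element is drawn with a configuration in one of them and without one in the other: 1 of 1 stereo elements differ; a stereocentre at a saturated chain carbon is drawn S in compound 2 and without a configuration in compound 3. The atoms and bonds are the same, so compound 3 reads as the same material with the configuration at the chain carbon left open. Going by the values given here, no measured step bears on a stereocentre drawn with and without a configuration; the one step in hand, a 1.5-fold higher number from compound 1 to compound 2 (0.16 log units; within the scatter), concerns a different change and stayed within the scatter. Whatever the unconfigured form contains, compound 2 is part of it, so compound 3 is expected to land close to compound 2, with any drift toward a higher number modest and probably inside the scatter. For compound 3 the expected step is a 1.2-fold higher number from compound 2 to compound 3 (0.09 log units; within the scatter). Compound 3 is therefore estimated at 5.5 nM in this assay, with a range from 2.5 nM to 13 nM.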

Compound 3, half-maximal inhibitory concentration: 3.5 nM
Compound 3: middle estimate off by 1.6-fold (0.20 log units), on the high side, within the range that was stated.
By their numbers in this assay, from the lowest: compounds 1, 3 and 2 (each within the scatter of the next).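

In this assay, leaving the configuration at the chain carbon open gives no change that can be told apart from the scatter: a 1.3-fold lower number from compound 2 to compound 3 (0.11 log units; within the scatter). The 1-methylbutyl group drawn without a configuration also stays level with pentan-3-yl on the same nitrogen, a 1.1-fold higher number from compound 1 to compound 3 (0.05 log units; within the scatter), so this branched chain reads the same against pentan-3-yl whether drawn as S or left open, which the earlier pair could show only for the S drawing. The pair still says little about the configuration itself, as the make-up of the open form is not given, and any reading of this step is limited because the two compounds differ only in how that one carbon is drawn: the fact that one of compounds 2 and 3 is drawn with a defined configuration and the other without, at the place where they differ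

From the compounds shown here alone, how the R form of the chain carbon, taken alone, would compare with the S form of compound 2 stays open. Also open, going by these compounds, is whether a longer chain, a cyclopropylmethyl group or a benzyl group on that nitrogen would hold the values in this same narrow band.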